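This account rests on a few compounds, and the source may have more. Where it says the series, first, only, none or still open, it means among the compounds named here.

Notes on the series built around compound 1 `O=C(Cn1c(-c2ccccc2)cc(-c2ccccc2)c1-c1ccco1)Nc1nc2ccccc2s1`. In an ADME assay on HEK-293T cells (Homo sapiens) for cytotoxicity, read by MTT assay, with a stated time of 72 h, tested at 50 uM (on this read-out lower numbers stand for less inhibition and higher numbers for more inhibition at the one concentration tested (going by the name of the read-out)), compound 1 gives 89.9%, the highest of the three numbers recorded so far. Compound 2 `O=C(Cn1c(-c2ccccc2)cc(-c2ccccc2)c1-c1ccco1)Nc1ccccn1` gives 69.4% in this assay, and compound 3 `O=C(Cn1c(-c2ccccc2)cc(-c2ccccc2)c1-c1ccccc1)Nc1nc2ccccc2s1` gives 55% in this assay. Both single changes from compound 1 lowered the read-out beyond the scatter: a number 20.5 percentage points lower from compound 1 to compound 2 (beyond the scatter) (pyridin-2-yl in place of 1,3-benzothiazol-2-yl on an amide-type nitrogen), and a number 34.9 percentage points lower from compound 1 to compound 3 (beyond the scatter) (phenyl in place of furan-2-yl on an aromatic carbon).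

Compound 4 `O=C(Cn1c(-c2ccc3ccccc3c2)cc(-c2ccccc2)c1-c1ccco1)Nc1nc2ccccc2s1` remains to be measured. It differs from compound 1 as follows: naphthalen-2-yl in place of phenyl on an aromatic carbon. Neither measured step matches this change directly: the step from compound 1 to compound 2 altered the amide-type nitrogen, and the step from compound 1 to compound 3 exchanged the furan-2-yl group, which sits two ring bonds from the carbon changed here. Both, however, show that a single ring exchange on the core of compound 1 moved the read-out beyond the scatter, in each recorded case downward. The expectation for compound 4 in this assay is therefore a modest downward step of a number 9.9 percentage points lower from compound 1 to compound 4 (within the scatter), though a number within the scatter of compound 1 cannot be excluded. The estimate for compound 4 is 80%, with a range from 58% to 97%.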

Compound 4, a percentage reported as inhibition, at one concentration (the size of the read-out at that concentration, not a potency): 38.3%
The estimate for compound 4 lay 41.7 percentage points above the measured number, outside the stated range (below it).
By their numbers in this assay, from the lowest: compound 4; then compound 3; then compound 2; then compound 1.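

The position on an aromatic carbon next to the ring nitrogen also responds in this assay: naphthalen-2-yl in place of phenyl gives a number 51.6 percentage points lower from compound 1 to compound 4 (beyond the scatter), so the read-out depends on this phenyl site as well as on the amide-type nitrogen and furan-2-yl sites changed earlier. All three single changes recorded from compound 1 now lower the number, and no recorded change goes against this, although the present change differs from the earlier two in adding to an existing aryl group, with one six-membered aromatic ring of carbon only replaced by 2 such rings, no hydrogen-bond donors or acceptors and no net charge on either group. Nothing available explains this step.

The compounds shown do not tell whether the step follows from the added ring itself or from the way naphthalen-2-yl is attached, and a methyl group or a phenyl carrying an amine or a carboxylic acid at this position could help separate these readings. They also leave open whether the same exchange would lower the number with pyridin-2-yl on the amide-type nitrogen.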